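A few compounds are considered here, and "the series" means these few. Any claim that something is new, unique, unknown or untested is made for them only; others in the source may bear on it.

Three compounds have been measured in a functional assay on PC-3 cells (Homo sapiens); on this read-out higher numbers stand for weaker inhibition of growth and lower numbers for stronger inhibition of growth:

Compound 1 `COc1ccc(-c2cc(O)c3cccnc3n2)cc1` gives 31600 nM.
Compound 2 `COc1ccccc1-c1cc(O)c2ccc(C)nc2n1` gives only a limit of the assay, > 100000 nM.
Compound 3 `COc1ccc(-c2cc(O)c3cc(C)cnc3n2)cc1` gives 5370 nM.

Compound 3 and compound 1 differ in one place (hydrogen in place of methyl on an aromatic carbon). That change produced a 5.9-fold higher number from compound 3 to compound 1 (0.77 log units; beyond the scatter), so losing the methyl weakened growth inhibition. How the core of compound 2 differs from the core of compound 3 is not broken down here.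

Compound 4 `COc1ccccc1-c1cc(O)c2cccnc2n1` is not yet measured. It differs from compound 2 by the same kind of change (hydrogen in place of methyl on an aromatic carbon), though the place is not the same: in compound 2 the methyl sits next to the ring nitrogen, whereas in compound 3 it sits two atoms from the ring nitrogen. Compound 2 already sits at the limit of > 100000 nM in this assay, at which 1 of the 3 values shown sits. A step like a 5.9-fold higher number from compound 3 to compound 1 (0.77 log units; beyond the scatter) would carry compound 4 further past that limit. The step expected here is a step that the limit leaves unreadable from compound 2 to compound 4. Compound 4 is therefore expected to give about 300000 nM in this assay, most probably reported again as a limit only.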

Compound 4, concentration for 50% growth inhibition: 29500 nM
Estimate against measurement, compound 4: 10-fold (1.01 log units) above, outside the stated range (below it).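

In this assay, hydrogen in place of methyl gave an at least 3.3-fold lower number from compound 2 to compound 4 (0.53 log units; beyond the scatter), which means stronger growth inhibition, whereas the same kind of change weakened growth inhibition on the other core, and the two steps clearly differ: the same change on two cores in this assay, a 5.9-fold higher number (0.77 log units; beyond the scatter) from compound 3 to compound 1 and an at least 3.3-fold lower number (0.53 log units; beyond the scatter) from compound 2 to compound 4, at least 19-fold (1.29 log units) apart, beyond the scatter of two such steps. Compound 2 gives > 100000 nM, which is a limit of the assay and not a number, and the full size of this step therefore cannot be read. The pairs show that this change does not carry over unchanged from one core to the other in this series, but they do not show what sets the difference, as the methyl leaves a different place in each pair and the cores differ as well.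

The compounds shown leave open what an ethyl group, a longer chain or an amine would do in place of the methyl. They also leave open how a methyl would act on the core of compound 4 in the place it holds in compound 3.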